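This account rests on a few compounds, and the source may have more. Where it says the series, first, only, none or still open, it means among the compounds named here.

Compound 1, `C[C@@H]1CN(c2sc(C(F)(F)F)nc2-c2nc3ccccc3[nH]2)CCN1C(=O)Cn1cc(Cl)cn1`: 251 nM
Compound 2, `Cc1nc(C)n(CC(=O)N2CCN(c3sc(C(F)(F)F)nc3-c3nc4cccc(C)c4[nH]3)C[C@H]2C)n1`: 376 nM

Both compounds were tested in a functional assay on Venous blood for antagonist activity at C-X-C chemokine receptor type 3 (Homo sapiens), read by flow cytometry, with a stated time of 30 min, in the presence of a further agent that is not named here; on this read-out lower numbers stand for stronger inhibition and higher numbers for weaker inhibition. On these numbers compound 1 holds the lowest of the two, but compound 2 lies within the usual scatter of it, so the two cannot be told apart on this read-out. Going by the values given here, they also differ from each other in more than one place, so no single step between measured compounds can be traced here.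

Compound 3, `C[C@@H]1CN(c2sc(C(F)(F)F)nc2-c2nc3ccccc3[nH]2)CCN1C(=O)Cn1cc(C2CCN(C)CC2)cn1`, has not yet been measured. It differs from compound 1 in one place: 1-methylpiperidin-4-yl in place of chloro on an aromatic carbon. Among the compounds with values here, no measured pair shows a change of this kind, so the size of the step has to be estimated without a direct precedent. The expectation is that a 1.4-fold lower number from compound 1 to compound 3 (0.14 log units; within the scatter) is small, leaning toward a lower number but not clearly beyond the scatter. Compound 3 is therefore expected to give 180 nM, within a range from 60 nM to 600 nM.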

Compound 3, half-maximal inhibitory concentration: 1690 nM
Compound 3: middle estimate off by 9.4-fold (0.97 log units), on the low side; measured number outside the range, above it.
By their numbers in this assay, from the lowest: compounds 1 and 2 (each within the scatter of the next); then compound 3.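

Replacing the single chlorine with 1-methylpiperidin-4-yl on this aromatic carbon gives a 6.7-fold higher number from compound 1 to compound 3 (0.83 log units; beyond the scatter) in this assay. Going by these compounds alone, this is the first one-place change, and it shows that the position is not indifferent to what it carries: here, seven heavy atoms, including a six-membered non-aromatic ring with a nitrogen, weaken inhibition compared with one chlorine atom. Nothing measured here explains the size or the direction of this step.

A single swap cannot separate the contribution of the ring from that of its nitrogen, or show how large a group this carbon can carry before inhibition falls. A cyclohexyl group, which keeps a six-membered ring without the nitrogen, and a small methyl group on the same carbon would each test part of this question.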